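Swapping the benzylic amine substituent on the piperidine ring

This account rests on a few compounds, and the source may have more. Where it says the series, first, only, none or still open, it means among the compounds named here.

The two measured compounds share a core and differ only at the amine attached to the piperidine ring. Compound 1 `c1ccc(CNC2CCN(CCCc3c[nH]c4ccc(-n5cnnc5)cc34)CC2)cc1` carries a benzylamino group; in an assay on CHO cells for agonist activity at 5-hydroxytryptamine receptor 1D (Homo sapiens), read by GTPgammaS binding (a higher number here means that more compound is needed for the effect, a lower number that less compound is needed), compound 1 gives 7.6 nM. Compound 2 `C[C@@H](NC1CCN(CCCc2c[nH]c3ccc(-n4cnnc4)cc23)CC1)c1ccccc1` adds a methyl on the chain carbon of that group, and in this assay compound 2 gives 13 nM. The step of a 1.7-fold higher number from compound 1 to compound 2 (0.23 log units; within the scatter) shows that this methyl changed little. Compound 2 therefore has the highest of the two numbers, but its nearest neighbour, compound 1, lies within the scatter of it, so no order between them can be read.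

Compound 3 `CN(Cc1ccsc1)C1CCN(CCCc2c[nH]c3ccc(-n4cnnc4)cc23)CC1` is not yet measured. Relative to compound 2 it differs as follows: methyl((thiophen-3-yl)methyl)amino in place of (1-phenylethyl)amino on a saturated ring carbon. For the measured compounds named here, no measured step covers a change of this kind; the only available step concerns a methyl on the chain carbon, and it was small. The expectation is therefore a number near that of compound 2, with a wide band for uncertainty, so compound 3 is expected to give 15 nM in this assay, between 4 nM and 60 nM. This estimate means the step of a 1.2-fold higher number from compound 2 to compound 3 (0.06 log units; within the scatter).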

Compound 3, half-maximal effective concentration: 4.2 nM
Compound 3: middle estimate off by 3.6-fold (0.55 log units), on the high side, within the range that was stated.
By their numbers in this assay, from the lowest: compounds 3, 1 and 2 (each within the scatter of the next, the first and the last beyond it).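

In this assay, for the compounds shown here, the exchange on the saturated ring carbon gives a 3.1-fold lower number from compound 2 to compound 3 (0.49 log units; beyond the scatter), the only step in this small set that lies beyond the scatter, so this position does respond to what is placed on it. The comparison with the unbranched group gives a 1.8-fold lower number from compound 1 to compound 3 (0.26 log units; within the scatter), which shows that the phenyl ring and the hydrogen-bond donor on the amine can both be given up without a change that rises above the scatter, and no order can be read between these two compounds. No measured evidence accounts for the step from compound 2, and the aromatic ring, the donor count and the defined stereocentre all change in it at once, so the data cannot assign the difference to any one of them.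

Going by these compounds, what stays open is how much each of those changes contributes on its own. A methyl(benzyl)amino group would separate the methyl on the amine from the change of aromatic ring, and a furan-3-ylmethyl group would test whether the sulfur of the thiophene can be replaced by oxygen.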